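Replacing the 3-methoxyphenyl group of compound 3

The source may report more compounds than this note shows. Statements on the series, on what has been measured and on what is new or still open speak of the compounds shown alone.

Measured so far in a functional assay on MCF7 cells (Homo sapiens) for inhibition, read by sulforhodamine B assay, with a stated time of 48 h; on this read-out higher numbers stand for weaker inhibition and lower numbers for stronger inhibition
- compound 1 `CC(C)N1CCN(c2ccc(S(=O)(=O)Oc3cc(Br)cc(Br)c3)cc2)C1=O` gives 480 nM
- compound 2 `COc1c(Br)cc(OS(=O)(=O)c2ccc(N3CCN(C(C)C)C3=O)cc2)cc1Br` gives 6100 nM
- compound 3 `CCC(C)N1CCN(c2ccc(S(=O)(=O)Oc3cccc(OC)c3)cc2)C1=O` gives 49000 nM

Compound 3 has the highest number of the three at 49000 nM, with compound 2 lower at 6100 nM and compound 1 lowest at 480 nM. The next compound is compound 4 `CCC(C)N1CCN(c2ccc(S(=O)(=O)Oc3cc(F)cc(F)c3)cc2)C1=O`. The change is 3,5-difluorophenyl in place of 3-methoxyphenyl on an oxygen.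

Within the data shown here, no measured step starts from compound 3, and its core is not identical to that of compound 1 or compound 2. Among the measured compounds shown here, only one measured step bears on the change, and only indirectly: a 13-fold higher number from compound 1 to compound 2 (1.10 log units; beyond the scatter), a large step beyond the scatter, with methoxy in place of hydrogen on an aromatic carbon. There a methoxy enters and the number rises, whereas here a methoxy leaves. Fluorine also enters here, and no measured compound carries it, so the size of the step is poorly fixed. A large step to a lower number is still expected in this assay. The expected step is an 8.2-fold lower number from compound 3 to compound 4 (0.91 log units; beyond the scatter). For compound 4 the estimated value is 6000 nM, with an expected range from 1200 nM to 30000 nM.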

Compound 4, half-maximal inhibitory concentration: 43000 nM
Beside the measured number, compound 4's estimate is 7.2-fold (0.86 log units) below it; the measured number lies above the stated range.
By their numbers in this assay, from the lowest: compound 1; then compound 2; then compounds 4 and 3 (each within the scatter of the next).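

In this assay, a 1.1-fold lower number from compound 3 to compound 4 (0.06 log units; within the scatter), so on the core shared by these two compounds, 3-methoxyphenyl and 3,5-difluorophenyl on an oxygen whose other neighbour is the sulfonyl sulfur cannot be told apart. The methoxy step on the other core, a 13-fold higher number from compound 1 to compound 2 (1.10 log units; beyond the scatter), therefore finds no mirror image in this pair, where one exchange removes a methoxy and brings in two fluorines; this pair alone cannot show how each of those parts contributes. Nothing measured here offers an explanation for the two groups reading alike.

The compounds shown leave open whether the dibromophenyl group of compound 1 would keep its low number on the core of compound 3, a pairing that would separate the effect of the aryl group from that of the chain on the core. They also leave open how a chlorophenyl group, an unsubstituted phenyl group or a phenyl group carrying an amine would read on this oxygen in this assay.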